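Third hydroxy on the phenyl ring: cytotoxicity outlook

A few compounds are considered here, and "the series" means these few. Any claim that something is new, unique, unknown or untested is made for them only; others in the source may bear on it.

Compound 1 `O=[N+]([O-])C1=CNc2nc(-c3ccco3)nn2C1` gives 108000 nM in an ADME assay on MDCK cells (Canis lupus familiaris) for cytotoxicity; a lower number here means that less compound is tolerated, a higher number that more compound is tolerated. Compound 2 `O=[N+]([O-])C1=CNc2nc(-c3ccco3)nn2C1c1ccc(O)cc1O` gives 119000 nM in this assay, which is the highest of the two plain numbers recorded, with compound 1 nearest: a 1.1-fold higher number from compound 1 to compound 2 (0.04 log units; within the scatter). Compound 3 `O=[N+]([O-])C1=CNc2ncnn2C1c1ccc(O)cc1O` returns only a limit in this assay, > 1080000 nM, and this is noted as the limit of > 1080000 nM in this assay, at which 1 of the 3 values shown sits. The step of an at least 9.0-fold higher number from compound 2 to compound 3 (0.95 log units; beyond the scatter) is therefore known only as a lower bound.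

Compound 4 `O=[N+]([O-])C1=CNc2nc(-c3ccco3)nn2C1c1ccc(O)c(O)c1O` differs from compound 2 by hydroxy in place of hydrogen on an aromatic carbon. For the measured compounds named here, of the measured steps, the one from compound 1 to compound 2 is the closest in kind, since it also altered the group on the saturated ring carbon while keeping the furan-2-yl group, and it stayed within the scatter. The step from compound 2 to compound 3 removed the furan-2-yl group and does not bear directly on a change on the phenyl ring. No step beyond the scatter is therefore expected in this assay for compound 4, in either direction. Compound 4 is estimated at 130000 nM, between 60000 nM and 300000 nM, which means an expected step of a 1.1-fold higher number from compound 2 to compound 4 (0.04 log units; within the scatter).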

Compound 4, half-maximal cytotoxic concentration: 317000 nM
Estimate against measurement, compound 4: 2.4-fold (0.39 log units) below; measured number outside the range, above it.
By their numbers in this assay, from the lowest: compounds 1 and 2 (each within the scatter of the next); then compound 4. At a limit, above all of these: compound 3.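

On the phenyl ring, the change registers in this assay: hydroxy in place of hydrogen on an aromatic carbon, ortho to two hydroxy groups, gives a 2.7-fold higher number from compound 2 to compound 4 (0.43 log units; beyond the scatter). For the compounds shown here, with the furan-2-yl group kept, this is the first step beyond the scatter, whereas the earlier change on the saturated ring carbon gave a 1.1-fold higher number from compound 1 to compound 2 (0.04 log units; within the scatter). More compound is therefore tolerated with this added hydroxy, but nothing shown gives a cause for the step.

On these data alone, whether a methoxy group, an amine or a carboxylic acid at this position would move the number in the same way remains open. As far as these compounds go, compound 3, which lacks the furan-2-yl group, stands only at a limit, > 1080000 nM, so whether the added hydroxy would shift the number without that group also remains open.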